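Chloro for hydrogen, carried from one core to another

This account rests on a few compounds, and the source may have more. Where it says the series, first, only, none or still open, it means among the compounds named here.

Compound 1 `CCOC(=O)c1c(C)oc2ncnc(Nc3ccc(OCc4cccc(Cl)c4)cc3)c12` and compound 2 `CCOC(=O)c1c(C)oc2ncnc(Nc3ccc(OCc4ccccc4)cc3)c12` share one core; compound 3 `Cc1oc2ncnc(Nc3ccccc3)c2c1C(=O)O` is built on another, and the difference between the two cores is not broken down here. In a functional assay on MCF7 cells (Homo sapiens) for cytotoxicity, read by MTT assay, with a stated time of 72 h (a lower number here means a stronger inhibitor, a higher number a weaker inhibitor), compound 1 gives 54000 nM. Compound 2 reaches only a limit of this assay, > 1000000 nM. Compound 3 gives 246000 nM in this assay, the highest of the two numbers shown, with compound 1 as its nearest measured neighbour.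

Within the data shown here, the one measured step is chloro in place of hydrogen on an aromatic carbon, which brought an at least 18-fold lower number from compound 2 to compound 1 (1.26 log units; beyond the scatter). The size of that step is known only as a lower bound, since compound 2 sits at the limit of > 1000000 nM in this assay, at which 1 of the 3 values shown sits.

Compound 4 `Cc1oc2ncnc(Nc3cccc(Cl)c3)c2c1C(=O)O` is the same change applied to compound 3: chloro in place of hydrogen on an aromatic carbon. The place of the chloro reads the same way in both pairs, so the change is the same, though it now sits on the other core. Compound 4 is expected to give a lower number than compound 3, with the step estimated as a 4.1-fold lower number from compound 3 to compound 4 (0.61 log units; beyond the scatter), which rests on an at least 18-fold lower number from compound 2 to compound 1 (1.26 log units; beyond the scatter) and is held back because compound 2 sits at the limit of > 1000000 nM in this assay, at which 1 of the 3 values shown sits, and the core has changed. Compound 4 is expected at 60000 nM, likely between 10000 nM and 250000 nM.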

Compound 4, half-maximal inhibitory concentration: 57500 nM
Compound 4: middle estimate off by 1.0-fold (0.02 log units), on the high side; the range from low to high includes it.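

On the core of compound 3, chloro in place of hydrogen again lowers the number in this assay, with a 4.3-fold lower number from compound 3 to compound 4 (0.63 log units; beyond the scatter), so the direction of the change holds on both cores shown. The size of the step does not carry over, and the two steps stand apart: the same change on two cores in this assay, an at least 18-fold lower number (1.26 log units; beyond the scatter) from compound 2 to compound 1 and a 4.3-fold lower number (0.63 log units; beyond the scatter) from compound 3 to compound 4, at least 4.3-fold (0.63 log units) apart, beyond the scatter of two such steps. These two pairs do not show how much of that gap belongs to the change of core, and the earlier step is only a lower bound, as compound 2 is the compound that sits at a limit of the assay rather than at a number: the limit of > 1000000 nM in this assay, at which 1 of the 4 values shown sits.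

Still open, on these data alone, is whether fluoro, methyl or methoxy in place of the same hydrogen would give a step like that of chloro on either core, and whether a pair on the core of compound 1 with both members giving true numbers would bring the two step sizes closer. Also open, as far as these compounds go, is how an amide or a nitrile in place of the carboxylic acid of compound 4 would read in this assay.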